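Phenyl for bromo on the shared core

This account rests on a few compounds, and the source may have more. Where it says the series, first, only, none or still open, it means among the compounds named here.

Of the compounds shown here, two of the shared core have been measured so far. Compound 1 `COc1ccc(-c2cn3cc(Br)nc(N)c3n2)cc1` and compound 2 `Nc1nc(Br)cn2cc(-c3ccco3)nc12` differ elsewhere on the core and both keep the bromo and the amino group. In an assay on cells for displacement of a labelled ligand from transmembrane domain-containing protein TMIGD3 (Homo sapiens), read by scintillation counting, with a stated time of 120 min, tested at 1 uM (on this read-out higher numbers stand for more inhibition at the one concentration tested (going by the name of the read-out) and lower numbers for less inhibition), compound 1 gives 24%, and in this assay compound 2 gives 28%. Among the compounds with values here, compound 2 stands highest of the two numbers as given, yet its only neighbour, compound 1, lies within the scatter of it, so the two are not separable on this read-out.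

Compound 3 `Nc1nc(-c2ccccc2)cn2cc(-c3ccco3)nc12` differs from compound 2 in one place: phenyl in place of bromo on an aromatic carbon. Within the data shown here, no step between measured compounds touches this position, so nothing measured so far says how a change there moves the read-out. With only the narrow spread between compound 1 and compound 2 to go on, the expected step of a number 2 percentage points higher from compound 2 to compound 3 (within the scatter) in this assay is small, of no set direction, and likely within the scatter. For compound 3 in this assay the estimate is 30%, with a range from 8% to 55%.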

Compound 3, a percentage reported as inhibition, at one concentration (the size of the read-out at that concentration, not a potency): 21%
Compound 3: middle estimate off by 9 percentage points, on the high side; the range from low to high includes it.
By their numbers in this assay, from the lowest: compounds 3, 1 and 2 (each within the scatter of the next).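

Within the data shown here, this is the first step at this position: phenyl in place of bromo on an aromatic carbon, next to the ring nitrogen, gives a number 7 percentage points lower from compound 2 to compound 3 (within the scatter) in this assay. Among these compounds, the bromo can therefore give way to a much larger group, a six-membered aromatic ring of carbon only, with no difference that this read-out can separate from scatter, so neither the bromo nor the phenyl stands out here, and a single concentration gives no potency for either compound. Nothing at hand offers a reason for this result.

One step with one aromatic group says little about how the position responds to other kinds of substituent, and a carboxylic acid, a piperidine or a short alkyl chain in place of the bromo could show whether anything here moves the number beyond the scatter. On these data alone, it also remains open whether the same exchange reads alike when the furan-bearing side of the shared core carries the other group, the methoxyphenyl of compound 1.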